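Methyl for fluoro on the aryl ring across two cores

This account rests on a few compounds, and the source may have more. Where it says the series, first, only, none or still open, it means among the compounds named here.

Compound 1 `O=C1/C(=C/c2ccc(F)cc2)Cc2ccccc21` is the reference point. In a functional assay on P388 cells (Mus musculus) for inhibition (a lower number here means a stronger inhibitor, a higher number a weaker inhibitor), compound 1 reaches only the limit > 50000 nM. Compound 2 `Cc1ccc(/C=C2\Cc3ccccc3C2=O)cc1` carries methyl in place of fluoro and in this assay compound 2 gives 38600 nM. The step of an at least 1.2-fold lower number from compound 1 to compound 2 (0.11 log units; that floor lies within the scatter) thus sits on a limit, as the limit of > 50000 nM in this assay, at which 1 of the 3 values shown sits, shows, and the change itself is methyl in place of fluoro on an aromatic carbon.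

Compound 3 `O=C1/C(=C/c2cccc(F)c2)CCc2ccccc21` has a different core; the difference between the two cores is not broken down here. In this assay compound 3 gives 31100 nM, and its value and that of compound 2 lie within the scatter of one another.

Compound 4 `Cc1cccc(/C=C2\CCc3ccccc3C2=O)c1` is still to be measured. It differs from compound 3 by methyl in place of fluoro on an aromatic carbon. The group sits meta to a large group here, whereas between compound 1 and compound 2 it sat para to a large group, so this is the same kind of change, not the same change.

The expected step of a 1.2-fold lower number from compound 3 to compound 4 (0.09 log units; within the scatter) rests on the step of an at least 1.2-fold lower number from compound 1 to compound 2 (0.11 log units; that floor lies within the scatter). Compound 4 is estimated at 25000 nM in this assay, between 9000 nM and 55000 nM.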

Compound 4, half-maximal inhibitory concentration: 16300 nM
The estimate for compound 4 lay 1.5-fold (0.19 log units) above the measured number, and the stated range covers the measured number.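

In this assay, methyl in place of fluoro on the core of compound 3 gives a 1.9-fold lower number from compound 3 to compound 4 (0.28 log units; within the scatter), so this pair shows no step beyond the scatter. Set beside the same change on the core of compound 1, the result does not establish either a shared or a different step size: the same change on two cores in this assay, an at least 1.2-fold lower number (0.11 log units; that floor lies within the scatter) from compound 1 to compound 2 and a 1.9-fold lower number (0.28 log units; within the scatter) from compound 3 to compound 4; the limit leaves it open whether they differ. The change can be said to have been read on both cores, but not to carry over with a fixed size, and the first of the two steps rests on a limit: the limit of > 50000 nM in this assay, at which 1 of the 4 values shown sits.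

The compounds shown hold only fluoro and methyl on the aromatic ring, leaving open whether an amine, a carboxylic acid or a longer chain in that place would give a step beyond the scatter on either core. Also open, from the compounds shown here alone, is how much the position of the group matters on a single core, as the two pairs differ in both core and position.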